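The compounds below may be only part of what the source reports. "The series", "measured", "known", "first", "only" and "open" are said of these compounds alone.

Values are from a functional assay on A549 cells (Homo sapiens) for cytotoxicity, read by sulforhodamine B assay; on this read-out lower numbers stand for stronger inhibition of growth and higher numbers for weaker inhibition of growth.

compound 1, `COc1ccc2c(c1)CCCCN2c1nc(Cl)nc2ccccc12`, gives 191 nM
compound 2, `COc1ccc2c(c1)CCCCN2c1nc(C)nc2ccccc12`, gives 21 nM
compound 3, `COc1ccc2c(c1)CCCN(c1nc(Cl)nc3ccccc13)C2`, gives 7570 nM

Compound 1 and compound 2 share one core and differ only by methyl in place of chloro on an aromatic carbon. That single change gives a 9.1-fold lower number from compound 1 to compound 2 (0.96 log units; beyond the scatter). Compound 3 carries the same atoms as compound 1 joined differently; the difference between the two cores is not broken down here. Among the three measured numbers compound 3 stands highest, beyond the scatter from compound 1 and far beyond it from compound 2.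

Compound 4, `COc1ccc2c(c1)CCCN(c1nc(C)nc3ccccc13)C2`, has not yet been measured in this assay. It relates to compound 3 exactly as compound 2 relates to compound 1: methyl in place of chloro on an aromatic carbon, the same change at the same place. Within the data shown here, the step is expected to be an 8.9-fold lower number from compound 3 to compound 4 (0.95 log units; beyond the scatter), resting on the single earlier instance a 9.1-fold lower number from compound 1 to compound 2 (0.96 log units; beyond the scatter). Among the measured compounds shown here, with only one instance known, and on a core that is itself rearranged, the range is kept wide. Compound 4 is expected to give about 850 nM, estimated between 300 nM and 2500 nM.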

Compound 4, concentration for 50% growth inhibition: 16700 nM
Compound 4: the middle estimate sits 20-fold (1.29 log units) below what was measured, outside the stated range (above it).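

In this assay, methyl in place of chloro on an aromatic carbon of the rearranged core gives a 2.2-fold higher number from compound 3 to compound 4 (0.34 log units; beyond the scatter), opposite in direction to the earlier step on the core of compound 1. The two instances of the same change do not agree: the same change on two cores in this assay, a 9.1-fold lower number (0.96 log units; beyond the scatter) from compound 1 to compound 2 and a 2.2-fold higher number (0.34 log units; beyond the scatter) from compound 3 to compound 4, 20-fold (1.30 log units) apart, beyond the scatter of two such steps. The step therefore does not carry from one core to the other in this pair of cores, but two instances show only that its size and direction depend on the core, not which feature of the cores decides this or what the step would be on a further core.

Open, from the compounds shown here alone, is whether other groups on this aromatic carbon between two ring nitrogen atoms, such as an amine or an ethyl group, would also split between the two cores. Also open, going by these compounds, is whether replacing the methoxy group with a hydroxyl or an amine would alter either step.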